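A few compounds are considered here, and "the series" means these few. Any claim that something is new, unique, unknown or untested is made for them only; others in the source may bear on it.

Measured compounds: compound 1 `O=C(CCCc1ccccc1)Nc1ccc(N2CCN(c3ccc(OC[C@@H]4CO[C@@](Cn5cncn5)(c5ccc(Cl)cc5Cl)O4)cc3)CC2)cc1` and compound 2 `O=C(CCc1ccccc1)Nc1ccc(N2CCN(c3ccc(OC[C@@H]4CO[C@@](Cn5cncn5)(c5ccc(Cl)cc5Cl)O4)cc3)CC2)cc1`.

In a functional assay on HepG2 cells (Homo sapiens) for inhibition, read by MTT assay, with a stated time of 48 h (a higher number here means a weaker inhibitor, a lower number a stronger inhibitor), compound 1 gives 10800 nM. In this assay compound 2 gives 5340 nM, the lowest of the two numbers seen so far, with compound 1 its nearest neighbour. Within the data shown here, the one measured step, a 2.0-fold lower number from compound 1 to compound 2 (0.31 log units; beyond the scatter), came from a shortening of the chain that links the amide carbonyl to the phenyl ring. Compound 3 `O=C(Nc1ccc(N2CCN(c3ccc(OC[C@@H]4CO[C@@](Cn5cncn5)(c5ccc(Cl)cc5Cl)O4)cc3)CC2)cc1)c1cccs1` is not yet measured; it differs from compound 2 by thiophen-2-yl in place of phenethyl on a carbonyl carbon, so the chain is removed altogether and a different aromatic ring sits directly on the carbonyl carbon. The measured step bears on this only in part, since it changed the chain length without changing the ring. For compound 3 a step of about a 1.3-fold lower number from compound 2 to compound 3 (0.13 log units; within the scatter) is therefore expected, at most modest and possibly within the scatter. Compound 3 is estimated at 4000 nM, with a range from 1500 nM to 12000 nM.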

Compound 3, half-maximal inhibitory concentration: 9770 nM
For compound 3 the middle estimate is 2.4-fold (0.39 log units) below the measured one, within the range that was stated.
By their numbers in this assay, from the lowest: compounds 2, 3 and 1 (each within the scatter of the next, the first and the last beyond it).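

In this assay, setting a thiophen-2-yl ring directly on the carbonyl carbon gives a 1.8-fold higher number from compound 2 to compound 3 (0.26 log units; within the scatter) and a 1.1-fold lower number from compound 1 to compound 3 (0.04 log units; within the scatter). Neither step lies beyond the scatter, so this position accepts the loss of the whole chain with no clear shift in the number, and the drop seen on shortening the chain cannot be extended as a trend to compound 3. Nothing at hand explains this result.

On these data alone, because the chain and the ring change together here, it stays open how much each contributes, which a phenyl ring set directly on the carbonyl carbon or a thiophen-2-yl ring at the end of a chain could help to separate. Also open, as far as these compounds go, is how this position responds to a pyridine ring or to a chain ending in an amine.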